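A few compounds are considered here, and "the series" means these few. Any claim that something is new, unique, unknown or untested is made for them only; others in the source may bear on it.

Compound 1 `Cc1ccccc1OCC1=NCCO1`: 40%
Compound 2 `Clc1ccccc1OCC1=NCCO1`: 80%

In a toxicity assay on the whole organism with Rattus norvegicus as the target, at a dose of 400 mg/kg by the oral route (on this read-out higher numbers stand for a stronger effect at the one dose given and lower numbers for a weaker effect), compound 2 stands highest of the two numbers; its nearest neighbour is compound 1, set apart from it by a gap beyond the scatter. Compound 3 `Fc1ccccc1OCC1=NCCO1` differs from compound 2 by fluoro in place of chloro on an aromatic carbon. Among the compounds with values here, the single measured step, a number 40 percentage points higher from compound 1 to compound 2 (beyond the scatter), is large and touches the same aromatic carbon, but it swaps a different group, so it tells only that this position moves this assay strongly. The direction for the present exchange is not fixed by the data, and the expected step of a number 25 percentage points lower from compound 2 to compound 3 (beyond the scatter) is taken as a moderate fall. Compound 3 is therefore estimated at 55%, with a range from 30% to 80%.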

Compound 3, a percentage reported as activity, at one dose (the size of the read-out at that dose, not a potency): 20%
Compound 3: middle estimate off by 35 percentage points, on the high side; measured number outside the range, below it.
By their numbers in this assay, from the lowest: compound 3; then compound 1; then compound 2.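

In this assay the exchange of one halogen for another on this aromatic carbon moves the number by a number 60 percentage points lower from compound 2 to compound 3 (beyond the scatter) and so counts as a large step in its own right. Methyl no longer marks the low end, since fluoro sits under it by a number 20 percentage points lower from compound 1 to compound 3 (beyond the scatter) and chloro sits above it. Nothing measured here bears on why chloro and fluoro part so widely. From the compounds shown here alone, it stays open how a bromo group or an amine on this same carbon would read, and whether the order of chloro, methyl and fluoro holds elsewhere on the ring.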